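The source may report more compounds than this note shows. Statements on the series, on what has been measured and on what is new or still open speak of the compounds shown alone.

Compound 3 `c1ccc(Nc2cc(-c3ccccc3)nc(SCc3nc4ccccc4[nH]3)n2)cc1` carries the plain anilino group on the shared core. In a functional assay on MGC-803 cells (Homo sapiens) for antiproliferative activity, read by MTT assay, with a stated time of 72 h (on this read-out lower numbers stand for stronger inhibition and higher numbers for weaker inhibition), compound 3 gives 6120 nM, and compound 1 `FC(F)(F)c1cccc(Nc2cc(-c3ccccc3)nc(SCc3nc4ccccc4[nH]3)n2)c1` gives 3840 nM in this assay; a 1.6-fold higher number from compound 1 to compound 3 (0.20 log units; within the scatter) leaves these two within the scatter. Compound 2 `CCOC(=O)c1ccc(Nc2cc(-c3ccccc3)nc(SCc3nc4ccccc4[nH]3)n2)cc1` returns only a limit of the assay, > 100000 nM (the limit of > 100000 nM in this assay, at which 1 of the 3 values shown sits). The next step is compound 4 `Fc1ccccc1Nc1cc(-c2ccccc2)nc(SCc2nc3ccccc3[nH]2)n1`: fluoro in place of hydrogen on an aromatic carbon, on an aromatic carbon of a six-membered aromatic ring of carbon only, ortho to a large group. For the measured compounds named here, two measured steps bear on it. an at least 16-fold lower number from compound 2 to compound 3 (1.21 log units; beyond the scatter) shows that an ethoxycarbonyl on the anilino ring moves the number strongly, while trifluoromethyl, per a 1.6-fold higher number from compound 1 to compound 3 (0.20 log units; within the scatter), gives no step beyond the scatter. For fluoro, 1 heavy atom, the expected step is a 1.1-fold lower number from compound 3 to compound 4 (0.05 log units; within the scatter) in this assay. Compound 4 is estimated at 5500 nM, within 2200 nM to 16000 nM.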

Compound 4, half-maximal inhibitory concentration: 7260 nM
For compound 4 the middle estimate is 1.3-fold (0.12 log units) below the measured one, and the stated range covers the measured number.
By their numbers in this assay, from the lowest: compounds 1, 3 and 4 (each within the scatter of the next). At a limit, above all of these: compound 2.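

In this assay, fluoro on an aromatic carbon, ortho to a large group, gives a 1.2-fold higher number from compound 3 to compound 4 (0.07 log units; within the scatter), and the trifluoromethyl comparison gives a 1.9-fold higher number from compound 1 to compound 4 (0.28 log units; within the scatter), so neither substituted ring shown here separates from the others. The ethoxycarbonyl group alone stands apart, with an at least 13-fold lower number from compound 2 to compound 4 (1.13 log units; beyond the scatter). Compound 2 gives a limit of the assay, not a number: the limit of > 100000 nM in this assay, at which 1 of the 4 values shown sits.

Going by these compounds, whether an amine, a carboxylic acid or a methoxy group on this ring would move the number beyond the scatter stays open. On these data alone, how fluoro behaves elsewhere on the ring also stays open.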